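Demethylation of the dimethoxybenzyl adenosine analogue

This account rests on a few compounds, and the source may have more. Where it says the series, first, only, none or still open, it means among the compounds named here.

The series shares the core of compound 1 `OC[C@H]1O[C@@H](n2cnc3c(NCc4cccc(Br)c4)ncnc32)[C@H](O)[C@@H]1O`. In a functional assay on HOS cells (Homo sapiens) for antiproliferative activity, with a stated time of 72 h (on this read-out lower numbers stand for stronger inhibition and higher numbers for weaker inhibition), compound 1 reaches only the limit of the assay, > 166000 nM. Compound 2 `COc1cccc(CNc2ncnc3c2ncn3[C@@H]2O[C@H](CO)[C@@H](O)[C@H]2O)c1OC` follows; the step here is a step that the two limits leave unreadable from compound 1 to compound 2. In this assay compound 2 likewise stops at the limit, > 166000 nM. Compound 2 therefore stands at the limit of > 166000 nM in this assay, at which 2 of the 2 values shown sit. Compound 3 `COc1cccc(CNc2ncnc3c2ncn3[C@@H]2O[C@H](CO)[C@@H](O)[C@H]2O)c1O` differs by hydrogen in place of methyl on an oxygen on an aromatic ring. For the measured compounds named here, the only measured step is unreadable, and nothing measured bears on hydrogen in place of methyl on an oxygen on an aromatic ring, so no shift beyond the scatter is expected, a step that the limit leaves unreadable from compound 2 to compound 3. Compound 3 is estimated at 200000 nM, range 100000 nM to 400000 nM, most probably again reported only as a limit.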

Compound 3, half-maximal inhibitory concentration: > 166000 nM
Compound 3: a limit, no number; the forecaster's own chance of this, stated with the estimate: 85%; the middle value does not contradict the limit.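

For the compounds shown here, compound 1, compound 2 and compound 3 all give limits rather than numbers, so no step among them can be read: the limit of > 166000 nM in this assay, at which 3 of the 3 values shown sit. The compounds shown leave open whether any of these replacements shifts the antiproliferative read-out at all.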